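The source may hold more compounds than are shown below. What is called first, only, known or untested is meant among the compounds shown, and "the series" means these compounds.

Measured compounds:
Compound 1, `CCCn1cc(C(N)=O)c2c(N)ncnc21`: in a functional assay on KB cells (Homo sapiens) for cytotoxicity (a higher number here means a weaker inhibitor, a lower number a stronger inhibitor), compound 1 gives 100000 nM.
Compound 2, `Cc1ccccc1Cn1cc(C(N)=O)c2c(N)ncnc21`: compound 2 reaches only the limit > 100000 nM in this assay.
Compound 3, `CCOCn1cc(C(N)=O)c2c(N)ncnc21`: compound 3 likewise reaches only the limit > 100000 nM in this assay.

Compound 3 thus stands at the edge of what this assay can report: it is recorded as a limit, not as a number, and two of the three values shown sit at that same limit, as the limit of > 100000 nM in this assay, at which 2 of the 3 values shown sit, shows. Compound 4, `C=CCn1cc(C(N)=O)c2c(N)ncnc21`, differs from compound 3 by vinyl in place of ethoxy on a saturated chain carbon bound to an aromatic nitrogen. The measured steps that touch compound 3 are a number no lower from compound 1 to compound 3 (the limit leaves the size open) and a step that the two limits leave unreadable from compound 2 to compound 3; the size of neither can be read because of the limit of > 100000 nM in this assay, at which 2 of the 3 values shown sit. All three measured compounds, which differ only on the saturated chain carbon bound to the aromatic nitrogen, sit at or near that limit, so a change on the same carbon gives no reason to expect a step beyond the scatter. Compound 4 is therefore expected to give about 100000 nM in this assay, within 30000 nM to 300000 nM. The expected step is a number no higher from compound 3 to compound 4 (the limit leaves the size open), most likely again only a limit.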

Compound 4, half-maximal inhibitory concentration: 100000 nM
Estimate against measurement, compound 4: no gap at the digits printed, and the stated range covers the measured number.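

In this assay the change made in compound 4 gives no change at the digits printed from compound 1 to compound 4 (within the scatter). Among the compounds shown here, this is the first step at this position with a real number at both ends, so this change, which brings in a double bond outside aromatic rings, now has a readable size, and that size lies within the scatter. The two other new steps are a number no higher from compound 2 to compound 4 (the limit leaves the size open) and a number no higher from compound 3 to compound 4 (the limit leaves the size open); their sizes cannot be read, because each starts from a limit: the limit of > 100000 nM in this assay, at which 2 of the 4 values shown sit.

As far as these compounds go, whether any group at this position can bring the number down remains open, for none of the four compounds shows a lower number than compound 1. An amine, a carboxylic acid or a longer chain at this place could answer that, and the compounds shown say nothing about changes elsewhere on the shared core.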